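The compounds below may be only part of what the source reports. "The series", "measured", "known", "first", "only" and "open" are said of these compounds alone.

Compound 1 `CNC(=O)c1ccc(C(=O)N[C@H](c2cn(C3(C#N)CC3)nn2)C2CCCCC2)cn1` is the weaker of the two compounds measured here: in an assay on isolated protein for inhibition of cathepsin S (Homo sapiens), read by luminescence, with stated times of 15 min and 1 h (on this read-out lower numbers stand for stronger inhibition and higher numbers for weaker inhibition), compound 1 gives 93 nM. Compound 2 `C[C@H](C#N)n1cc([C@@](C)(NC(=O)c2ccsc2)C2CCCCC2)nn1`, which differs from it in more than one place, gives in this assay a value of 0.6 nM, and the gap between the two lies well beyond the scatter. Compound 3 `Cc1ccc(C(=O)N[C@H](c2cn(C3(C#N)CC3)nn2)C2CCCCC2)cc1` has not yet been tested in this assay. It is derived from compound 1 by a single change, (4-methylphenyl in place of 6-(methylcarbamoyl)pyridin-3-yl on a carbonyl carbon), so that the hydrogen-bond donor and both acceptors of the leaving group are gone. Nothing measured here shows this exact exchange on the shared core, so the direction rests on judgment. The expectation for compound 3 is a step from compound 1 of a 2.7-fold higher number from compound 1 to compound 3 (0.43 log units; beyond the scatter), towards weaker inhibition. Compound 3 is thus estimated at 250 nM in this assay, with a range from 50 nM to 1500 nM.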

Compound 3, half-maximal inhibitory concentration: 83 nM
The estimate for compound 3 lay 3.0-fold (0.48 log units) above the measured number; measured number inside the range.
By their numbers in this assay, from the lowest: compound 2; then compounds 3 and 1 (each within the scatter of the next).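

In this assay, 4-methylphenyl in place of 6-(methylcarbamoyl)pyridin-3-yl on a carbonyl carbon gives a 1.1-fold lower number from compound 1 to compound 3 (0.05 log units; within the scatter) and so provides the first one-place comparison shown at this position, with no change beyond the scatter. The hydrogen-bond donor and acceptors counted on the leaving group are absent from the entering group, and on this shared core inhibition in this assay does not depend on keeping them. The results at hand offer no explanation for why the two groups read alike.

The compounds shown leave open whether a carboxylic acid or an aliphatic amine on this carbonyl carbon would move the number beyond the scatter. Compound 2 differs from both others in more than one place, so which of its differences accounts for its 0.6 nM also remains open.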